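The compounds below may be only part of what the source reports. "The series", "measured", "known", "first", "only" and "open" are said of these compounds alone.

Of the compounds shown here, two that share one core have so far been tested in a functional assay for inhibition, read by spectrophotometry, with a stated time of 20 min, tested at 3 mg/mL; a higher number here means a stronger effect of the compound at the concentration tested, a lower number a weaker effect. Compound 1 `CC(=O)c1ccc(NC(=O)C(CC(C)C)N(C(=O)c2ccccc2)S(=O)(=O)c2ccc(C)cc2)cc1` gives 63.1% in this assay. Compound 2 `CC(=O)c1ccc(NC(=O)CN(C(=O)c2ccccc2)S(=O)(=O)c2ccc([N+](=O)[O-])cc2)cc1` gives 20.6% in this assay, the lower of the two numbers, and its gap to compound 1 lies beyond the usual scatter. For the measured compounds named here, the two structures differ in more than one place, so these two values show only that compound 2 has the weaker effect at the concentration tested.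

Compound 3 `CC(=O)c1ccc(NC(=O)C(CC(C)C)N(C(=O)c2ccccc2)S(=O)(=O)c2ccc([N+](=O)[O-])cc2)cc1` has not yet been measured. It differs from compound 2 in a single place: isobutyl in place of hydrogen on a saturated chain carbon bound to an amide-type nitrogen and a carbonyl carbon. Compound 1 carries that same isobutyl group and gives 63.1%, which suggests the change may lift the inhibition. The step from compound 2 to compound 3 in this assay is expected to be upward and beyond the scatter, a number 24.4 percentage points higher from compound 2 to compound 3 (beyond the scatter). Compound 3 is therefore estimated at 45%, within a range from 22% to 68%.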

Compound 3, a percentage reported as inhibition, at one concentration (the size of the read-out at that concentration, not a potency): 62.3%
For compound 3 the middle estimate is 17.3 percentage points below the measured one; the measured number falls inside the stated range.
By their numbers in this assay, from the lowest: compound 2; then compounds 3 and 1 (each within the scatter of the next).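

With the nitro group held the same, isobutyl in place of hydrogen on the saturated chain carbon now stands alone as a single change, and in this assay it gives a number 41.7 percentage points higher from compound 2 to compound 3 (beyond the scatter) at this position, something the first two compounds, which differed in more than one place, could not show. Nitro in place of methyl on an aromatic carbon gives a number 0.8 percentage points lower from compound 1 to compound 3 (within the scatter) in the same assay, so with isobutyl present this swap stays within the scatter. No measurement at hand explains why isobutyl has this effect.

The compounds shown leave open whether methyl, a longer chain or a chain ending in an amine would act like isobutyl on this carbon. They also leave open what a carboxylic acid would give on the aromatic carbon, and whether nitro and methyl would still match with hydrogen on the chain carbon.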